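This account rests on a few compounds, and the source may have more. Where it says the series, first, only, none or still open, it means among the compounds named here.

In a functional assay, with a stated time of 60 min (a higher number here means a weaker inhibitor, a lower number a stronger inhibitor), compound 1 (`O=C(/C=C/c1ccc(O)cc1)OCCOc1no[n+]([O-])c1S(=O)(=O)c1ccccc1`) gives 6240000 nM and compound 2 (`O=C(OCCOc1no[n+]([O-])c1S(=O)(=O)c1ccccc1)c1ccc(O)c(O)c1`) gives 275000 nM, the lower of the two numbers. Compound 3 (`O=C(/C=C/c1ccccc1)OCCOc1no[n+]([O-])c1S(=O)(=O)c1ccccc1`) has not yet been measured. Its structure differs from that of compound 2 as follows: 2-phenylethenyl in place of 3,4-dihydroxyphenyl on a carbonyl carbon. In words, 2-phenylethenyl stands in place of 3,4-dihydroxyphenyl on a carbonyl carbon. Within the data shown here, the one measured step that bears on this is large, a 23-fold lower number from compound 1 to compound 2 (1.36 log units; beyond the scatter), and it was a similar swap in the opposite direction. A large rise is therefore expected, and the estimated step is a 9.1-fold higher number from compound 2 to compound 3 (0.96 log units; beyond the scatter). The estimated value for compound 3 is 2500000 nM, with an expected range of 400000 nM to 12000000 nM.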

Compound 3, half-maximal inhibitory concentration: > 10000000 nM
Compound 3: only a limit was reported; the forecaster's own chance of this, stated with the estimate: 10%; middle value at least 4.0-fold (0.60 log units) away from the limit.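

Compound 3 carries only a limit, not a number: the limit of > 10000000 nM in this assay, at which 1 of the 3 values shown sits. Even so, 2-phenylethenyl in place of 3,4-dihydroxyphenyl on the carbonyl carbon gives an at least 36-fold higher number from compound 2 to compound 3 (1.56 log units; beyond the scatter), which marks a much weaker inhibitor. Hydrogen in place of hydroxy on an aromatic carbon gives an at least 1.6-fold higher number from compound 1 to compound 3 (0.20 log units; that floor lies within the scatter), so the effect of that hydroxy cannot be read.

Compound 2 and compound 3 differ in both the ring hydroxy groups and the ethenyl link, and these two changes remain unseparated. On these data alone, whether an amine or a carboxylic acid on the aromatic ring could match 3,4-dihydroxyphenyl also remains open.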